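Shortening the Hydroxybutynyl Chain: An Estimate

A few compounds are considered here, and "the series" means these few. Any claim that something is new, unique, unknown or untested is made for them only; others in the source may bear on it.

Measured compounds:
compound 1, `OCC#CCSc1cnc2ccccc2c1SCC#CCCl`, gives 5.1 ug/mL in a functional assay on P388 cells (Mus musculus) for antiproliferative activity, with a stated time of 72 h; on this read-out higher numbers stand for weaker inhibition and lower numbers for stronger inhibition
compound 2, `OCC#CCSc1cnc2ccccc2c1[Se]CC#CCCl`, gives 2 ug/mL
compound 3, `OCC#CCSc1cnc2ccccc2c1Cl`, gives 2.4 ug/mL

Compound 1 holds the highest of the three numbers, so it is the weakest inhibitor among them: a 2.6-fold lower number from compound 1 to compound 2 (0.41 log units; beyond the scatter) and a 2.1-fold lower number from compound 1 to compound 3 (0.33 log units; beyond the scatter), both beyond the scatter, while compound 2 and compound 3 lie within the scatter of each other (a 1.2-fold higher number from compound 2 to compound 3 (0.08 log units; within the scatter)).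

Compound 4, `CSc1cnc2ccccc2c1SCC#CCCl`, differs from compound 1 in one respect: hydrogen in place of 3-hydroxyprop-1-yn-1-yl on a saturated chain carbon bound to a sulfur. All three measured steps alter the other group, the one attached to the aromatic carbon, and every measured compound keeps the 4-hydroxybut-2-yn-1-yl chain intact. For the measured compounds named here, no measured step therefore bears on this change, and the three known values span only a narrow band. On that thin basis, compound 4 is expected to show a 1.0-fold lower number from compound 1 to compound 4 (0.01 log units; within the scatter), a step not beyond the scatter, though with wide uncertainty. Compound 4 is estimated at 5 ug/mL, with a range from 1.5 ug/mL to 15 ug/mL.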

Compound 4, concentration for 50% inhibition: 2.7 ug/mL
Beside the measured number, compound 4's estimate is 1.9-fold (0.27 log units) above it, and the stated range covers the measured number.
By their numbers in this assay, from the lowest: compounds 2, 3, 4 and 1 (each within the scatter of the next, the first and the last beyond it).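

For the compounds shown here, this is the first step that touches the 4-hydroxybut-2-yn-1-yl chain: in this assay, cutting it back to methyl gives a 1.9-fold lower number from compound 1 to compound 4 (0.28 log units; within the scatter). Compound 1 and compound 4 therefore cannot be told apart on this read-out, so for this one pair, the loss of the 3-hydroxyprop-1-yn-1-yl part, with its triple bond and its hydroxyl, brings no change that can be read. Nothing available explains this result.

On these data alone, only compound 1 has a methyl partner, so it remains open whether the same cut would read alike with the chlorine of compound 3 or the selenium-linked chain of compound 2 on the aromatic carbon. As far as these compounds go, it is also open how a longer saturated chain, or a chain ending in an amine or a carboxylic acid, would behave in this place.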